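The source may report more compounds than this note shows. Statements on the series, on what has been measured and on what is new or still open speak of the compounds shown alone.

Of the compounds shown here, two have been measured in an assay on isolated protein (Oryctolagus cuniculus) for inhibition of Calpain-2 catalytic subunit (Homo sapiens), at pH 8.0; on this read-out lower numbers stand for stronger inhibition and higher numbers for weaker inhibition. Compound 1 `CCOC(=O)C(=O)C(CC)NC(=O)C(CC(C)C)NC(=O)OCc1ccccc1` gives 400 nM. Within the data shown here, compound 2 `CCOC(=O)C(=O)C(CC)NC(=O)C(CC(C)C)NC(=O)C(CC)Oc1ccccc1` gives 1400 nM, which is the higher of the two numbers; the single measured step, a 3.5-fold higher number from compound 1 to compound 2 (0.54 log units; beyond the scatter), lies beyond the scatter. Compound 3 `CCOC(=O)C(=O)C(CC)NC(=O)C(CC(C)C)NC(=O)OCC(C)C` has not been measured. It differs from compound 2 in one place: isobutoxy in place of 1-phenoxypropyl on a carbonyl carbon. The change drops the aromatic ring that compound 2 carries and puts an oxygen-linked group back on the carbonyl carbon, as in compound 1, though with isobutoxy rather than benzyloxy. Among the measured compounds shown here, only the step from compound 1 to compound 2 bears on this. Reversing its kind of change is expected to bring the number down again, while the loss of the ring leaves the size uncertain. The step expected here is a 2.0-fold lower number from compound 2 to compound 3 (0.30 log units; within the scatter). Compound 3 is estimated at 700 nM, with a range from 250 nM to 2000 nM.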

Compound 3, inhibition constant: 17000 nM
The estimate for compound 3 lay 24-fold (1.39 log units) below the measured number; the measured number lies above the stated range.
By their numbers in this assay, from the lowest: compound 1; then compound 2; then compound 3.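

In this assay, the change to isobutoxy on a carbonyl carbon bound to an amide-type nitrogen gives a 12-fold higher number from compound 2 to compound 3 (1.08 log units; beyond the scatter), a much larger move than a 3.5-fold higher number from compound 1 to compound 2 (0.54 log units; beyond the scatter). Restoring an oxygen-linked group therefore does not by itself bring the number down: isopropyl in place of phenyl on the saturated chain carbon gives a 43-fold higher number from compound 1 to compound 3 (1.63 log units; beyond the scatter), and among these three compounds, the two carrying an aromatic ring have the lower numbers, with none going against this. No measurement here explains why the number rises so sharply.

As far as these compounds go, it remains open whether the aromatic ring itself matters or simply the larger group. A cyclohexylmethoxy group on the same carbonyl carbon, which has a saturated ring instead of an aromatic one, would help separate these two possibilities.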